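The source may report more compounds than this note shows. Statements on the series, on what has been measured and on what is new or still open speak of the compounds shown alone.

Measured so far in a functional assay on the whole organism (strain Wistar) for inhibition, with Rattus norvegicus as the target, read by paw edema, with a stated time of 4 h, at a dose of 10 mg/kg by the intraperitoneal route; a lower number here means less inhibition, a higher number more inhibition at the dose given (going by the name of the read-out):

Compound 1, `O=C(N/N=C/c1cccc(F)c1)c1cccnc1Nc1cccc(C(F)(F)F)c1`, gives 29.8%.
Compound 2, `O=C(N/N=C/c1ccc(F)cc1)c1cccnc1Nc1cccc(C(F)(F)F)c1`, gives 36.5%.
Compound 3, `O=C(N/N=C/c1ccc(Cl)cc1)c1cccnc1Nc1cccc(C(F)(F)F)c1`, gives 43.7%.

Compound 3 carries the highest of the three numbers, but only the gap to compound 1 is beyond the scatter: a number 13.9 percentage points higher from compound 1 to compound 3 (beyond the scatter). The gap to compound 2 is not: a number 7.2 percentage points higher from compound 2 to compound 3 (within the scatter). Likewise the step of a number 6.7 percentage points higher from compound 1 to compound 2 (within the scatter) stays within the scatter. Across the three compounds, then, the one change that registered was from 3-fluorophenyl to 4-chlorophenyl on the carbon with a double bond to nitrogen.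

Compound 4, `O=C(N/N=C/c1cccc(O)c1)c1cccnc1Nc1cccc(C(F)(F)F)c1`, is not yet measured. It differs from compound 3 in one place: 3-hydroxyphenyl in place of 4-chlorophenyl on a carbon with a double bond to nitrogen.

Within the data shown here, no measured step carries a hydroxyl group, so none bears directly on this change. Among the measured compounds shown here, the only step touching a 3-substituted phenyl at this position is the one from compound 1 to compound 3, and it was a modest rise on going to 4-chlorophenyl. Going back to a 3-substituted phenyl, the expectation for compound 4 is a modest fall from compound 3, roughly the size of that earlier step, with wide uncertainty: a number 13.7 percentage points lower from compound 3 to compound 4 (beyond the scatter). Compound 4 is therefore estimated at 30% in this assay, with a range of 18% to 42%.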

Compound 4, a percentage reported as inhibition, in the whole organism at one dose (the size of the read-out at that dose, not a potency): 35.8%
Compound 4: middle estimate off by 5.8 percentage points, on the low side; the range from low to high includes it.
By their numbers in this assay, from the lowest: compounds 1, 4, 2 and 3 (each within the scatter of the next, the first and the last beyond it).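

In this assay, among these compounds, the hydroxyl group is the first group on this phenyl ring to carry a hydrogen-bond donor and acceptor, and none of the three steps to compound 4 registers: 3-hydroxyphenyl in place of 4-chlorophenyl on a carbon with a double bond to nitrogen gives (a number 7.9 percentage points lower from compound 3 to compound 4 (within the scatter)), 3-hydroxyphenyl in place of 4-fluorophenyl gives (a number 0.7 percentage points lower from compound 2 to compound 4 (within the scatter)), and hydroxy in place of fluoro gives (a number 6 percentage points higher from compound 1 to compound 4 (within the scatter)). The gap beyond the scatter between compound 1 and compound 3 therefore does not extend to every 3-substituted phenyl, since compound 1 stands beyond the scatter of compound 3 while compound 4 does not. Nothing measured here explains this difference between compound 1 and compound 4.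

Among the compounds shown, this position holds only fluoro, chloro and hydroxy on the phenyl ring, so the response to an amine or a carboxylic acid on that ring remains open. Also open, from the compounds shown here alone, is whether a longer chain in place of the phenyl ring would move the number beyond the scatter of compound 3.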